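The source may hold more compounds than are shown below. What is called first, only, known or untested is meant among the compounds shown, and "the series" means these compounds.

Compound 1 `CCOc1ccc(Br)cc1-c1cc(Nc2ccc(C#N)cc2)nc(N)n1` gives 17 nM in an assay on Sf9 cells for inhibition of 1-acyl-sn-glycerol-3-phosphate acyltransferase beta (Homo sapiens); on this read-out higher numbers stand for weaker inhibition and lower numbers for stronger inhibition. Going by the values given here, compound 2 `CCOc1ccc(Br)cc1-c1cc(Nc2ccc(C(C)=O)cc2)nc(N)n1` gives 34 nM in this assay, and the only single-point step among the measured compounds is a 2.0-fold higher number from compound 1 to compound 2 (0.30 log units; within the scatter). Compound 3 `CCOc1ccc(Cl)cc1-c1cc(Nc2ccc(Cl)cc2)nc(N)n1` gives 17 nM in this assay, level with compound 1 at the digits shown, while compound 2 stands within the scatter of both.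

Compound 4 `CCOc1ccc(Br)cc1-c1cc(Nc2ccc(Cl)cc2)nc(N)n1` differs from compound 3 by bromo in place of chloro on an aromatic carbon. Among the compounds with values here, no measured step tests this particular swap: the step from compound 1 to compound 2 concerns a different position of the molecule. Compounds 1 and 3, which differ in two places at once, one of them this same halogen position, return the same number in this assay, which gives no hint of a shift from either halogen. On that basis the step of no change at the digits printed from compound 3 to compound 4 (within the scatter) is expected to stay within the scatter, and compound 4 is estimated at 17 nM in this assay, with a likely range from 8 nM to 35 nM.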

Compound 4, half-maximal inhibitory concentration: 16 nM
Estimate against measurement, compound 4: 1.1-fold (0.03 log units) above; the range from low to high includes it.
By their numbers in this assay, from the lowest: compounds 4, 1, 3 and 2 (each within the scatter of the next, the first and the last beyond it).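

In this assay, the halogen at the place para to an ethoxy group now has a direct test, and a 1.1-fold lower number from compound 3 to compound 4 (0.03 log units; within the scatter) shows that bromo and chloro cannot be told apart there. With bromo held constant, compound 4 also adds a direct comparison at the other substituted position: a 1.1-fold lower number from compound 1 to compound 4 (0.03 log units; within the scatter) leaves chloro and cyano level within the scatter, while a 2.1-fold lower number from compound 2 to compound 4 (0.33 log units; beyond the scatter) is a modest step that gives the first separation beyond the scatter among these compounds. Nothing available gives a reason for these steps. Going by these compounds, whether the number would hold with an amine or a carboxylic acid at the halogen place remains open. So does the outcome of a longer chain, such as propoxy, in place of the ethoxy group.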